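From ethoxycarbonyl to carboxy against an assay limit

A few compounds are considered here, and "the series" means these few. Any claim that something is new, unique, unknown or untested is made for them only; others in the source may bear on it.

Measured in a functional assay on HepG2 cells (Homo sapiens) for cytotoxicity, with a stated time of 72 h; a higher number here means that more compound is needed for the effect, a lower number that less compound is needed:
- Compound 1 `C=C[C@@](C)(/C=C/c1ccc(O)c(C=O)c1)CCC=C(C)C`, a limit only: > 52000 nM
- Compound 2 `C=C[C@@](C)(/C=C/c1ccc(O)c(/C=C/C#N)c1)CCC=C(C)C`, a limit only: > 52000 nM
- Compound 3 `C=C[C@@](C)(/C=C/c1ccc(O)c(/C=C/C(=O)OCC)c1)CCC=C(C)C`, a limit only: > 52000 nM

Compound 3 stands at > 52000 nM in this assay, and this is a limit, not a number. The whole set looks the same: the limit of > 52000 nM in this assay, at which 3 of the 3 values shown sit.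

The next structure is compound 4 `C=C[C@@](C)(/C=C/c1ccc(O)c(/C=C/C(=O)O)c1)CCC=C(C)C`. The change is hydrogen in place of ethyl on an oxygen next to a carbonyl group, which means hydrogen in place of ethyl on an oxygen next to a carbonyl group, so 2-(ethoxycarbonyl)ethenyl becomes 2-carboxyethenyl.

Within the data shown here, three measured steps bear on this change: a step that the two limits leave unreadable from compound 1 to compound 2, a step that the two limits leave unreadable from compound 1 to compound 3 and a step that the two limits leave unreadable from compound 2 to compound 3. None of them has a readable size, so they offer no number to carry over, and they point in no direction. With only such steps as a step that the two limits leave unreadable from compound 2 to compound 3 to go on, compound 4 is expected to show no step beyond the scatter in this assay, and the most likely report is again only a limit.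

The expected size is a step that the limit leaves unreadable from compound 3 to compound 4. For compound 4 the estimated value is 60000 nM, within an expected range from 30000 nM to 120000 nM.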

Compound 4, half-maximal effective concentration: > 52000 nM
Compound 4: a limit, no number (the forecaster's own chance of this, stated with the estimate: 90%); the middle value is on the limit's open side.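

Compound 4 gives only a limit in this assay, as do compound 1, compound 2 and compound 3, so no new step can be read among them: the limit of > 52000 nM in this assay, at which 4 of the 4 values shown sit. The compounds shown leave open how much of each would be needed for the effect, and whether carboxy in place of ethoxycarbonyl changes that amount at all.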